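Working notes: from compound 2 to compound 3

The source may report more compounds than this note shows. Statements on the series, on what has been measured and on what is new or still open speak of the compounds shown alone.

Compound 1 `O=C(OCCO)OCCc1ccc(O)c(O)c1` gives "not determined" (no result reported) in an ADME assay on MRC5 cells (Homo sapiens) for inhibition, read by MTT assay, with a stated time of 72 h; a lower number here means a stronger inhibitor, a higher number a weaker inhibitor
Compound 2 `CCCCCCCCOC(=O)OCCc1ccc(O)c(O)c1` gives 37900 nM in this assay

Among the compounds with values here, compound 2 holds the only number, so it cannot yet be ranked against any other compound. Compound 1 gives no result to compare with it. The next compound to be measured is compound 3 `O=C(OCCc1ccc(O)c(O)c1)OCCc1ccc(O)c(O)c1`, which has 3,4-dihydroxyphenyl in place of hexyl on a saturated chain carbon, two bonds along the chain from an oxygen next to a carbonyl group. Within the data shown here, no measured pair shows what a change of this kind does in this assay, so no direction can be argued from the data. The expectation therefore stays anchored on compound 2 at 37900 nM, with no shift beyond the usual scatter. The expected size of the step is a 1.1-fold lower number from compound 2 to compound 3 (0.03 log units; within the scatter), and this remains an estimate with wide uncertainty. For compound 3 the estimated value is 35000 nM, with an expected range from 10000 nM to 120000 nM.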

Compound 3, half-maximal inhibitory concentration: > 50000 nM
Compound 3: only a limit was reported; the forecaster's own chance of this, stated with the estimate: 20%; at least 1.4-fold (0.15 log units) between middle value and limit.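

The change on a saturated chain carbon, two bonds along the chain from an oxygen next to a carbonyl group, 3,4-dihydroxyphenyl in place of hexyl, gives an at least 1.3-fold higher number from compound 2 to compound 3 (0.12 log units; that floor lies within the scatter) in this assay and brings no lower number. For compound 3, > 50000 nM is a limit of the assay and not a number. On these data alone, the step can be read only as a floor, and its true size stays open, because the result for compound 3 is a limit: the limit of > 50000 nM in this assay, at which 1 of the 3 values shown sits.

The compounds shown leave open whether another group at this position, such as an amine, a carboxylic acid or a longer chain, would move the number beyond the scatter. Compound 1 gives "not determined" (no result reported) and so adds no second number for comparison with compound 2.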